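The compounds below may be only part of what the source reports. "The series", "measured", "known", "first", "only" and "open" are said of these compounds alone.

Compound 1 `CC(C)(C)c1ccc(C(=O)N2CCC3(CC2)C(=O)N(CC(=O)NCCC(=O)O)CN3c2ccccc2)cc1` gives 11400 nM in an assay on HEK293 cells for displacement of a labelled ligand from NPC1-like intracellular cholesterol transporter 1 (Homo sapiens); on this read-out higher numbers stand for weaker inhibition and lower numbers for stronger inhibition.
Compound 2 `CC(C)(C)c1ccc(C(=O)N2CCC3(CC2)C(=O)N(CC(=O)NCCCN)CN3c2ccccc2)cc1` gives 4200 nM in this assay.
Compound 3 `CC(C)(C)c1ccc(C(=O)N2CCC3(CC2)C(=O)N(CC(=O)NCN)CN3c2ccccc2)cc1` gives 26500 nM in this assay.

All three compounds share one core and differ only in the chain attached to the amide-type nitrogen. Compound 3 stands at the highest number of the three: compound 1 shows a 2.3-fold higher number from compound 1 to compound 3 (0.37 log units; beyond the scatter), and compound 2 shows a 6.3-fold higher number from compound 2 to compound 3 (0.80 log units; beyond the scatter). Between compound 1 and compound 2 the step is a 2.7-fold lower number from compound 1 to compound 2 (0.43 log units; beyond the scatter).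

Compound 4 `CC1CCCN(C(=O)CN2CN(c3ccccc3)C3(CCN(C(=O)c4ccc(C(C)(C)C)cc4)CC3)C2=O)C1` has not been measured. The change from compound 3 is 3-methylpiperidin-1-yl in place of (aminomethyl)amino on a carbonyl carbon

The three measured steps all concern the end of an open chain on the amide-type nitrogen and were modest in size, the largest being a 6.3-fold higher number from compound 2 to compound 3 (0.80 log units; beyond the scatter). Among the compounds with values here, none of them replaces the whole (aminomethyl)amino group with a ring, so there is no direct precedent for the change to compound 4. The measured steps do show that this part of the molecule shifts the number modestly in either direction, and compound 3 is already the highest of the set. Compound 4 is therefore expected to move modestly, most likely toward a lower number, as a 2.9-fold lower number from compound 3 to compound 4 (0.47 log units; beyond the scatter), with the direction uncertain.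

For compound 4 the estimated value in this assay is 9000 nM, with a range from 2500 nM to 40000 nM.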

Compound 4, half-maximal inhibitory concentration: 12000 nM
Compound 4: middle estimate off by 1.3-fold (0.12 log units), on the low side, and the stated range covers the measured number.
By their numbers in this assay, from the lowest: compound 2; then compounds 1 and 4 (each within the scatter of the next); then compound 3.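

Every earlier compound ended in an open chain, and compound 4 shows that this carbonyl carbon can also carry 3-methylpiperidin-1-yl, a six-membered ring with no counted hydrogen-bond donors, with a 2.2-fold lower number from compound 3 to compound 4 (0.34 log units; beyond the scatter) when it replaces the short (aminomethyl)amino group. The same ring in place of (2-carboxyethyl)amino gives a 1.1-fold higher number from compound 1 to compound 4 (0.02 log units; within the scatter), so these two groups cannot be told apart on this read-out, whereas in place of (3-aminopropyl)amino it gives a 2.9-fold higher number from compound 2 to compound 4 (0.46 log units; beyond the scatter), which leaves compound 2 with the lowest number of the four and so the strongest inhibition. Nothing shown here explains why these groups rank as they do.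

The compounds shown leave open what the methyl group on the ring contributes, a question that plain piperidin-1-yl at the same carbonyl carbon would address. They also leave open whether a piperidine ring carrying an amine, or a longer chain such as (4-aminobutyl)amino, would bring the number below that of compound 2.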